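The source may report more compounds than this note shows. Statements on the series, on what has been measured and on what is new or still open speak of the compounds shown alone.

Measured so far in a functional assay on A549 cells (Homo sapiens) for antiproliferative activity, read by MTT assay, with a stated time of 24 h; on this read-out lower numbers stand for stronger inhibition and higher numbers for weaker inhibition:
Compound 1 `FC(F)(F)c1ccc(C2CC(c3ccccc3)=NN2c2ccc(-c3ccccc3)nn2)cc1`: 9160 nM
Compound 2 `Clc1ccc(C2=NN(c3ccc(-c4ccccc4)nn3)C(c3ccccc3)C2)cc1`: 96700 nM
Compound 3 `FC(F)(F)c1ccc(C2CC(c3ccc(Cl)cc3)=NN2c2ccc(-c3ccccc3)nn2)cc1`: > 100000 nM

Compound 3 stands at the top of the set. For compound 3 the value in this assay is a limit of the assay and not a number, and it is the limit of > 100000 nM in this assay, at which 1 of the 3 values shown sits. Among the numbers shown, compound 1 gives the lowest one; the step of an at least 10-fold higher number from compound 1 to compound 3 (1.03 log units; beyond the scatter) lies beyond the scatter, while the step of an at least 1.0-fold higher number from compound 2 to compound 3 (0.01 log units; that floor lies within the scatter) stays within it, so the two measured steps tell only that compound 3 is weaker than compound 1 and not separated from compound 2.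

Compound 4 `COc1cc(C2CC(c3ccc(Cl)cc3)=NN2c2ccc(-c3ccccc3)nn2)cc(OC)c1OC` differs from compound 3 in one place: 3,4,5-trimethoxyphenyl in place of 4-(trifluoromethyl)phenyl on a saturated ring carbon. For the measured compounds named here, neither measured step concerns this group, so no measured step bears directly on the change; both steps involve substituents on an aromatic carbon elsewhere. With compound 3 known only as a limit, the starting point itself is uncertain. The step of an at least 2.5-fold lower number from compound 3 to compound 4 (0.39 log units; beyond the scatter) is therefore offered as a loose expectation rather than a prediction. Compound 4 is estimated at 40000 nM in this assay, with a range from 4000 nM to 200000 nM.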

Compound 4, half-maximal inhibitory concentration: 83300 nM
Compound 4: middle estimate off by 2.1-fold (0.32 log units), on the low side, within the range that was stated.
By their numbers in this assay, from the lowest: compound 1; then compounds 4 and 2 (each within the scatter of the next). At a limit, above all of these: compound 3.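

In this assay, the step of a 1.2-fold lower number from compound 2 to compound 4 (0.06 log units; within the scatter) stays within the scatter, so with the 4-chlorophenyl group held in place, 3,4,5-trimethoxyphenyl and phenyl on the saturated ring carbon cannot be told apart, even though the entering group brings 3 hydrogen-bond acceptors that phenyl lacks. The comparison with 4-(trifluoromethyl)phenyl at the same carbon gives an at least 1.2-fold lower number from compound 3 to compound 4 (0.07 log units; that floor lies within the scatter), and since that floor also lies within the scatter, this exchange shows no separation either. Compound 3 remains a limit of the assay and not a number: the limit of > 100000 nM in this assay, at which 1 of the 4 values shown sits.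

The compounds shown leave open whether 3,4,5-trimethoxyphenyl on this carbon would read differently with phenyl in place of the 4-chlorophenyl group, the pairing in which compound 1, with its 4-(trifluoromethyl)phenyl, gives the lowest number. They also leave open how a ring bearing an amine or a carboxylic acid, or a short alkyl chain in place of the ring, would read at this carbon.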